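This account rests on a few compounds, and the source may have more. Where it says the series, first, only, none or still open, it means among the compounds named here.

Working notes on the cytotoxicity series.

Compound 1 `O=[N+]([O-])c1cn2c(n1)OC(COCc1ccc(OC(F)(F)F)cc1)C2` is the parent of the first pair. In an ADME assay on MRC5 cells (Homo sapiens) for cytotoxicity, read by fluorescence, with a stated time of 72 h (a higher number here means a weaker inhibitor, a lower number a stronger inhibitor), compound 1 gives > 64000 nM, which is a limit of the assay rather than a number. Compound 2 `CC1(COCc2ccc(OC(F)(F)F)cc2)Cn2cc([N+](=O)[O-])nc2O1` carries methyl in place of hydrogen on a saturated ring carbon. In this assay compound 2 gives 60000 nM. The step of an at least 1.0-fold lower number from compound 1 to compound 2 (0.02 log units; that floor lies within the scatter) therefore sits at the floor set by that limit. The second pair rests on compound 3 `O=[N+]([O-])c1cn2c(n1)OC(COc1ccc(-c3ccc(C(F)(F)F)cc3)cc1)C2`; the difference between the core of compound 3 and the core of compound 1 is not broken down here. In this assay compound 3 gives > 64000 nM, again a limit of the assay. Compound 4 `CC1(COc2ccc(-c3ccc(C(F)(F)F)cc3)cc2)Cn2cc([N+](=O)[O-])nc2O1` is not yet measured and carries methyl in place of hydrogen on a saturated ring carbon, the same change as that from compound 1 to compound 2. Two of the three known values rest on (the limit of > 64000 nM in this assay, at which 2 of the 3 values shown sit). Compound 4 is expected to show a number no higher from compound 3 to compound 4 (the limit leaves the size open), beside the earlier step, since the pair compound 1 and compound 2 gave an at least 1.0-fold lower number from compound 1 to compound 2 (0.02 log units; that floor lies within the scatter). The estimate for compound 4 in this assay is 64000 nM, with an expected range from 30000 nM to 100000 nM.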

Compound 4, half-maximal inhibitory concentration: > 64000 nM
Compound 4 was reported as a limit; the forecaster's own chance of this, stated with the estimate: 70%; the middle value lies on the limit itself.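

In this assay compound 4 gives > 64000 nM, a limit of the assay. Compound 3 gives > 64000 nM, also a limit, so no step between compound 3 and compound 4 can be read: the limit of > 64000 nM in this assay, at which 3 of the 4 values shown sit.

The compounds shown leave open whether methyl in place of hydrogen on a saturated ring carbon changes the number for compound 4 at all.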